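Replacing methyl with phenylsulfonyl on the ring amine nitrogen

The compounds below may be only part of what the source reports. "The series", "measured", "known", "first", "only" and "open" are said of these compounds alone.

In an ADME assay on L02 cells (Homo sapiens) for cytotoxicity, read by MTT assay, with a stated time of 24 h (a lower number here means a stronger inhibitor, a higher number a weaker inhibitor), compound 1 (`CN1C/C(=C\c2ccncc2)C(=O)/C(=C/c2ccccc2F)C1`) gives 14900 nM, compound 2 (`CN1C/C(=C\c2ccncc2)C(=O)/C(=C/c2ccc(F)cc2Br)C1`) gives 12400 nM and compound 3 (`CN1C/C(=C\c2ccncc2)C(=O)/C(=C/c2ccc(C#N)cc2)C1`) gives 14000 nM. These three values lie within the scatter of one another, so compound 1 has no distinct rank among them.

Compound 4 (`O=C1/C(=C/c2ccncc2)CN(S(=O)(=O)c2ccccc2)C/C1=C\c1ccccc1F`) keeps the 2-fluorophenyl group of compound 1 and carries phenylsulfonyl in place of methyl on an amine nitrogen in a ring.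

The measured steps bear on this change only indirectly, since all of them exchange the aryl group and none touches this nitrogen. They are a 1.2-fold lower number from compound 1 to compound 2 (0.08 log units; within the scatter), a 1.1-fold lower number from compound 1 to compound 3 (0.03 log units; within the scatter) and a 1.1-fold higher number from compound 2 to compound 3 (0.05 log units; within the scatter), each within the scatter. For the measured compounds named here, no measured step therefore gives a direction for the new group, and no shift beyond the scatter is expected, though with low confidence. The estimated change is a 1.2-fold lower number from compound 1 to compound 4 (0.09 log units; within the scatter). For compound 4 the expected value is 12000 nM, with an estimated range of 4000 nM to 30000 nM.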

Compound 4, half-maximal inhibitory concentration: 15900 nM
Beside the measured number, compound 4's estimate is 1.3-fold (0.12 log units) below it, and the stated range covers the measured number.
By their numbers in this assay, from the lowest: compounds 2, 3, 1 and 4 (each within the scatter of the next).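

In this assay, for the compounds shown here, the amine nitrogen in the ring now has a measured step of its own (a 1.1-fold higher number from compound 1 to compound 4 (0.03 log units; within the scatter)), whereas the earlier steps exchanged only the aryl group. Even this large exchange, with phenylsulfonyl entering in place of methyl, stays within the scatter, and compound 4 cannot be separated from compound 1 at this position. No measurement among the data bears on why the two compounds cannot be separated.

The reading rests on one pair carrying the 2-fluorophenyl group, leaving open whether phenylsulfonyl gives the same result with the 2-bromo-4-fluorophenyl or 4-cyanophenyl groups of compound 2 and compound 3. Also open, going by these compounds, is whether an acetyl group, a benzyl group or a longer alkyl chain on this nitrogen would give a step beyond the scatter.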